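The source may report more compounds than this note shows. Statements on the series, on what has been measured and on what is new or still open speak of the compounds shown alone.

Compound 1 `C=C1CC[C@@H]2[C@](C)(CO)[C@H](O)CC[C@@]2(C)[C@@H]1CC(Sc1ccc(C)cc1)C1=CCOC1=O` and compound 2 `C=C1CC[C@@H]2[C@](C)(CO)[C@H](O)CC[C@@]2(C)[C@@H]1CC(Sc1ccc(F)cc1)C1=CCOC1=O` share one core; compound 3 `C=C1CC[C@@H]2[C@](C)(CO)[C@H](O)CC[C@@]2(C)[C@@H]1C/C=C1/C(=O)OC[C@H]1OC(=O)CSc1ccc(C)cc1` and compound 4 `C=C1CC[C@@H]2[C@](C)(CO)[C@H](O)CC[C@@]2(C)[C@@H]1C/C=C1/C(=O)OC[C@H]1OC(=O)CSc1ccc(F)cc1` share another, and the difference between the two cores is not broken down here. In a functional assay on PC-3 cells (Homo sapiens) for inhibition, read by MTT assay, with a stated time of 48 h (a higher number here means a weaker inhibitor, a lower number a stronger inhibitor), compound 1 gives 29000 nM and compound 2 gives 16000 nM, so that a 1.8-fold lower number from compound 1 to compound 2 (0.26 log units; within the scatter) with fluoro in place of methyl on an aromatic carbon. Compound 3 gives 27000 nM in this assay, close to compound 1. Compound 4 carries the same change as compound 2 does, (fluoro in place of methyl on an aromatic carbon), at a place described in the same words. Because a 1.8-fold lower number from compound 1 to compound 2 (0.26 log units; within the scatter) stayed within the scatter, a step of about the same size, a 1.7-fold lower number from compound 3 to compound 4 (0.23 log units; within the scatter), is expected for compound 4, resting only on that single earlier pair. Compound 4 is therefore estimated at 16000 nM in this assay, between 8000 nM and 32000 nM.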

Compound 4, half-maximal inhibitory concentration: 14000 nM
Beside the measured number, compound 4's estimate is 1.1-fold (0.06 log units) above it; measured number inside the range.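

In this assay there is a 1.9-fold lower number from compound 3 to compound 4 (0.29 log units; within the scatter) with fluoro in place of methyl on an aromatic carbon, and the change reads alike on the two cores: the same change on two cores in this assay, a 1.8-fold lower number (0.26 log units; within the scatter) from compound 1 to compound 2 and a 1.9-fold lower number (0.29 log units; within the scatter) from compound 3 to compound 4, 1.1-fold (0.03 log units) apart, within the scatter of two such steps

The change thus carries from the core of compound 1 to the core of compound 3 with a step of similar small size. Both steps lie within the scatter, however, so neither pair shows that the change really moves the number, and two pairs say nothing about any further core.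

The compounds shown hold only methyl and fluoro at this place, so it stays open how a chloro, a methoxy or an amine there would read in this assay on either core.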